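The source may report more compounds than this note shows. Statements on the series, on what has been measured and on what is new or still open speak of the compounds shown alone.

In an assay on isolated protein for inhibition of phosphodiesterase 4A (Sus scrofa) (a higher number here means a weaker inhibitor, a lower number a stronger inhibitor), three amides built on one shared core have been measured. Compound 1 `COc1ccc(C(=O)Nc2ccccc2SC)cc1OC1CCCC1` gives 1200 nM, compound 2 `COc1ccc(C(=O)Nc2cccnc2)cc1OC1CCCC1` gives 550 nM, and compound 3 `COc1ccc(C(=O)Nc2nccs2)cc1OC1CCCC1` gives 6500 nM. Compound 3 therefore stands with the highest number of the three, meaning the weakest inhibition: its nearest neighbour is compound 1, separated by a 5.4-fold higher number from compound 1 to compound 3 (0.73 log units; beyond the scatter), and the widest gap is a 12-fold higher number from compound 2 to compound 3 (1.07 log units; beyond the scatter).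

Compound 4 `COc1ccc(C(=O)Nc2ncccc2C)cc1OC1CCCC1` differs from compound 3 in a single place: 3-methylpyridin-2-yl in place of 1,3-thiazol-2-yl on an amide-type nitrogen. Among the measured compounds shown here, two measured steps bear on this change. Both a 5.4-fold higher number from compound 1 to compound 3 (0.73 log units; beyond the scatter) and a 12-fold higher number from compound 2 to compound 3 (1.07 log units; beyond the scatter) show that the five-membered ring on the amide-type nitrogen came with a higher number than either six-membered ring tried there, and the six-membered ring with one nitrogen in compound 2 gave the lowest number of the three. For the measured compounds named here, compound 4 also carries a six-membered ring with one nitrogen, though with a methyl on it, and for that methyl no measured step exists. The expectation for compound 4 is therefore a drop in this assay of roughly a 7.2-fold lower number from compound 3 to compound 4 (0.86 log units; beyond the scatter), a step well beyond the scatter. The estimate for compound 4 is 900 nM, with a likely range from 300 nM to 3000 nM.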

Compound 4, half-maximal inhibitory concentration: 3100 nM
The estimate for compound 4 lay 3.4-fold (0.54 log units) below the measured number; measured number above the stated range.
By their numbers in this assay, from the lowest: compound 2; then compound 1; then compound 4; then compound 3.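

In this assay, a 2.1-fold lower number from compound 3 to compound 4 (0.32 log units; beyond the scatter) shows that replacing 1,3-thiazol-2-yl with 3-methylpyridin-2-yl lowers the number only modestly, so a six-membered aromatic ring with one nitrogen does not by itself give a low number at this position. The other two steps place compound 4 in the middle of the series, with a 5.6-fold higher number from compound 2 to compound 4 (0.75 log units; beyond the scatter) and a 2.6-fold higher number from compound 1 to compound 4 (0.41 log units; beyond the scatter), so the two pyridine-type groups now fall on opposite sides of the 2-(methylsulfanyl)phenyl group and ring type alone does not set the order. Nothing measured here explains these differences.

Compound 2 and compound 4 differ in both the methyl and the point at which the ring is attached, so the compounds shown cannot divide the step between those two features, whereas a plain pyridin-2-yl group would separate them. On these data alone, it also remains open how this position would respond if the methyl of 3-methylpyridin-2-yl were replaced by an amine or a longer chain such as propyl.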